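This account rests on a few compounds, and the source may have more. Where it says the series, first, only, none or still open, it means among the compounds named here.

Three compounds share a core in which a hydrazone links an aryl aldehyde to an aminothiazole bearing a second aryl group. Compound 1 `Fc1ccc(/C=N/Nc2nc(-c3ccc(C(F)(F)F)cc3)cs2)cc1F`, compound 2 `COc1cc(/C=N/Nc2nc(-c3ccc(Br)cc3)cs2)cc(Br)c1OC` and compound 3 `Fc1ccc(/C=N/Nc2nc(-c3cc(C(F)(F)F)cc(C(F)(F)F)c3)cs2)cc1F` were tested in a functional assay on U-87MG ATCC cells for inhibition, with U-87 MG (Homo sapiens) as the target, read by MTT assay, with a stated time of 48 h; a higher number here means a weaker inhibitor, a lower number a stronger inhibitor. In this assay compound 1 gives 29900 nM, compound 2 gives 27900 nM and compound 3 gives 29700 nM. Compound 2 carries the lowest of the three numbers, yet both compound 1 and compound 3 sit within the usual scatter of it, so the three cannot be told apart on these data, and the varied aryl groups of compounds 1 and 3 on either side of the core leave the read-out essentially unchanged.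

Compound 4 `COc1ccccc1-c1csc(N/N=C/c2cc(Br)c(OC)c(OC)c2)n1` has not yet been measured. It differs from compound 2 in one place: 2-methoxyphenyl in place of 4-bromophenyl on an aromatic carbon. Since the three measured compounds, with quite different aryl substituents, all return the same read-out within scatter, the step from compound 2 to compound 4 is expected to stay within that scatter as well, in no particular direction, giving a 1.1-fold higher number from compound 2 to compound 4 (0.03 log units; within the scatter). Compound 4 is therefore estimated at 30000 nM, with a range from 15000 nM to 60000 nM.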

Compound 4, half-maximal inhibitory concentration: > 100000 nM
Compound 4: a limit, no number; the forecaster's own chance of this, stated with the estimate: 20%; middle value at least 3.3-fold (0.52 log units) away from the limit.
By their numbers in this assay, from the lowest: compounds 2, 3 and 1 (each within the scatter of the next). At a limit, above all of these: compound 4.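

Until now the read-out had not moved beyond the scatter, but this position shows that it can: in this assay, 2-methoxyphenyl in place of 4-bromophenyl on the aromatic carbon next to the ring nitrogen gives an at least 3.5-fold higher number from compound 2 to compound 4 (0.55 log units; beyond the scatter). As far as these compounds go, the reading for compound 4 is a limit of the assay and not a number, so the true size of the step stays unknown: the limit of > 100000 nM in this assay, at which 1 of the 4 values shown sits. The exchange removes the bromine, brings in a methoxy group and moves the substituent to a different place on the phenyl ring, and this single step does not separate these changes.

Left open is whether 4-methoxyphenyl or 2-bromophenyl at this position would stay with compound 2 or go the way of compound 4, which would separate the identity of the substituent from its place on the phenyl ring. Also open, from the compounds shown here alone, are how an unsubstituted phenyl, or a phenyl carrying an amine or a carboxylic acid, would read here, and whether 2-methoxyphenyl has the same effect with the aryl group that compound 1 carries on the other side of the core.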